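From ethoxycarbonyl to carbamoyl on an iodo compound

A few compounds are considered here, and "the series" means these few. Any claim that something is new, unique, unknown or untested is made for them only; others in the source may bear on it.

In a functional assay on HeLa cells (Homo sapiens) (on this read-out higher numbers stand for an effect only at larger amounts of compound and lower numbers for an effect already at smaller amounts), compound 1 `CCOC(=O)c1cc(CCl)[nH]n1` shows only a limit, > 100 ug/mL. Among the compounds with values here, compound 2 `CCOC(=O)c1cc(CCl)nn1C1O[C@@H](COC(C)=O)[C@H](OC(C)=O)[C@@H](OC(C)=O)[C@@H]1OC(C)=O` gives 40 ug/mL, and compound 3 `CCOC(=O)c1cc(CI)nn1C1O[C@@H](COC(C)=O)[C@H](OC(C)=O)[C@@H](OC(C)=O)[C@@H]1OC(C)=O` gives 2.5 ug/mL, the lower of the two actual numbers so far. Compound 4 `CC(=O)OC[C@@H]1OC(n2nc(CI)cc2C(N)=O)[C@@H](OC(C)=O)[C@H](OC(C)=O)[C@H]1OC(C)=O` keeps the iodo group of compound 3 and differs at one other place: amino in place of ethoxy on a carbonyl carbon. This is amino in place of ethoxy on a carbonyl carbon, which turns ethoxycarbonyl into carbamoyl.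

Within the data shown here, no measured step touches that group, so the data give no direct size for this change. Among the measured compounds shown here, the one measured step, a 16-fold lower number from compound 2 to compound 3 (1.20 log units; beyond the scatter), is iodo in place of chloro at a different place. It sets no size here, but it does show that a single swap can move the numbers in this assay a long way, and that argues for a wide range. Starting from compound 3 at 2.5 ug/mL, only a small move towards a higher number is expected, with a wide margin on either side. The expected change is a 2.0-fold higher number from compound 3 to compound 4 (0.30 log units; within the scatter). Compound 4 is estimated at 5 ug/mL, with an expected range from 1.2 ug/mL to 25 ug/mL.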

Compound 4, concentration for half-maximal effect: 2 ug/mL
Estimate against measurement, compound 4: 2.5-fold (0.40 log units) above, and the stated range covers the measured number.
By their numbers in this assay, from the lowest: compounds 4 and 3 (each within the scatter of the next); then compound 2. At a limit, above all of these: compound 1.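

In this assay, amino in place of ethoxy on the carbonyl carbon gives a 1.3-fold lower number from compound 3 to compound 4 (0.10 log units; within the scatter), so with the iodo group kept, ethoxycarbonyl and carbamoyl cannot be told apart on this read-out. The earlier compounds shown here all carried ethoxycarbonyl and so said nothing about this place; now it is clear that ethoxy, with its 3 heavy atoms, can give way to amino, with 1 heavy atom and 1 hydrogen-bond donor, without a change beyond the scatter. This comparison rests on two actual numbers, not on the one limit in the series: the limit of > 100 ug/mL in this assay, at which 1 of the 4 values shown sits.

Only these two groups are shown on this carbonyl carbon, so it remains open whether a carboxylic acid, a longer ester chain such as butoxy, or an amide with a methyl group on its nitrogen would also stay within the scatter of compound 3. It is also open whether the same swap would give a similar result in the chloro compound 2, since this change is shown only in the iodo pair.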